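A few compounds are considered here, and "the series" means these few. Any claim that something is new, unique, unknown or untested is made for them only; others in the source may bear on it.

Compound 2 `C=CCc1cc(C(C)=O)c(O)cc1OCCCC` stands lowest of the two numbers measured in an assay on isolated protein for inhibition of leukotriene B4 receptor 1 (Homo sapiens), tested at 10 uM; a lower number here means less inhibition, a higher number more inhibition at the concentration tested (going by the name of the read-out): compound 2 gives 32%. Its nearest neighbour is compound 1 `C=CCc1cc(C(C)=O)c(O)cc1OCCCCCCC#N`, which in this assay gives 97%. Among the compounds with values here, the single step joining the two, a number 65 percentage points lower from compound 1 to compound 2 (beyond the scatter), is the only measured step available, and it shows that taking the 2-cyanoethyl group off the end of the chain costs most of the inhibition.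

Compound 3 `C#CCCCCOc1cc(O)c(C(C)=O)cc1CC=C` is the next step from compound 2: ethynyl in place of hydrogen on a saturated chain carbon, four bonds along the chain from an oxygen on an aromatic ring. This puts a chain extension back at the very place where the 2-cyanoethyl group was removed, so the step from compound 1 to compound 2 bears on it directly, although the entering ethynyl group is not the same as the group that left. Because a number 65 percentage points lower from compound 1 to compound 2 (beyond the scatter) was large, a sizeable rise is expected in this assay, roughly a number 38 percentage points higher from compound 2 to compound 3 (beyond the scatter), though the different end group makes the size uncertain. Compound 3 is therefore estimated at 70%, with a range from 40% to 95%.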

Compound 3, a percentage reported as inhibition, at one concentration (the size of the read-out at that concentration, not a potency): 74%
For compound 3 the middle estimate is 4 percentage points below the measured one; the measured number falls inside the stated range.
By their numbers in this assay, from the lowest: compound 2; then compound 3; then compound 1.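

In this assay, within the data shown here, ethynyl at the end of the chain brings back much of the inhibition, with a number 42 percentage points higher from compound 2 to compound 3 (beyond the scatter), so the 2-cyanoethyl group is not the only end group that gives a large gain at this place, and a nitrile is not required for it. The two end groups are still not interchangeable, with a number 23 percentage points lower from compound 1 to compound 3 (beyond the scatter), so the identity of the group matters as well as its presence. Nothing measured here explains why either group raises the inhibition.

Going by these compounds, whether the rise needs a triple bond at all, or whether a plain saturated longer chain would give the same gain, stays open. On these data alone, it is also open how an amine or a carboxylic acid at the end of the chain would fare in this assay.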